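A few compounds are considered here, and "the series" means these few. Any claim that something is new, unique, unknown or untested is made for them only; others in the source may bear on it.

Compound 1 `CCCC(=O)NCCC(=O)c1cc(OC)ccc1N` opens a small set of compounds that share one core and differ only in the group that sits on the amide carbonyl carbon; in a functional assay for inhibition of kynurenine 3-monooxygenase (Rattus norvegicus), tested at 1 mM (on this read-out higher numbers stand for more inhibition at the one concentration tested (going by the name of the read-out) and lower numbers for less inhibition), compound 1 gives "not determined" (no result reported), so no number stands for it. Compound 2 `COc1ccc(N)c(C(=O)CCNC(=O)C2CCC2)c1` carries a cyclobutyl there and in this assay compound 2 gives 92.2%. Compound 3 `COc1ccc(N)c(C(=O)CCNC(=O)C2CCCCC2)c1` carries a cyclohexyl and in this assay compound 3 gives 99.6%, the highest of the two numbers in hand, yet the step of a number 7.4 percentage points higher from compound 2 to compound 3 (within the scatter) lies within the scatter, so the two compounds cannot be placed in any order.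

Compound 4 `COc1ccc(N)c(C(=O)CCNC(=O)c2ccccc2)c1` differs from compound 3 by one change: phenyl in place of cyclohexyl on a carbonyl carbon. For the measured compounds named here, no measured step swaps a non-aromatic ring for an aromatic one, so the only step in hand bears on this one merely by analogy: changing the ring on that carbonyl carbon from cyclobutyl to cyclohexyl moved the read-out only within the scatter. Because compound 3 gives 99.6%, there is little room above it, and the expected step of a number 9.6 percentage points lower from compound 3 to compound 4 (within the scatter) is a small one, most likely not beyond the scatter. For compound 4 the estimate in this assay is 90%, expected to fall between 70% and 100%.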

Compound 4, a percentage reported as inhibition, at one concentration (the size of the read-out at that concentration, not a potency): 97.2%
Compound 4: the middle estimate sits 7.2 percentage points below what was measured; low and high end bracket the measured number.
By their numbers in this assay, from the lowest: compounds 2, 4 and 3 (each within the scatter of the next).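

Replacing the non-aromatic cyclohexyl with the aromatic phenyl on this carbonyl carbon gives a number 2.4 percentage points lower from compound 3 to compound 4 (within the scatter) and replacing cyclobutyl with phenyl gives a number 5 percentage points higher from compound 2 to compound 4 (within the scatter) so in this assay the three compounds cannot be placed in any order. For the compounds shown here, the earlier pair compared only two non-aromatic rings of different size, whereas this result extends the comparison to an aromatic ring of carbon only, and all three ring types now give numbers within the scatter of one another, though a percentage at one concentration is not a potency and cannot show whether they differ in potency. No measurement in hand explains why these rings read alike.

Whether a ring is needed here at all remains open, since the one compound without a ring on this carbonyl carbon has no number: compound 1 gives "not determined" (no result reported) in this assay and a longer chain is also absent from the compounds shown. Also open, going by these compounds, is how this read-out would respond to a ring containing nitrogen, such as piperidine, to a chlorophenyl or to a carboxylic acid in this place.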